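This account rests on a few compounds, and the source may have more. Where it says the series, first, only, none or still open, it means among the compounds named here.

Working notes on the series. In an assay (Rattus norvegicus) for inhibition of Fatty-acid amide hydrolase 1 (Homo sapiens) (on this read-out lower numbers stand for stronger inhibition and higher numbers for weaker inhibition), compound 1 `Cc1cccnc1-c1cnc(C(=O)CCCCCCc2ccccc2)o1` gives 15 nM. Compound 2 `Cc1ccc(-c2cnc(C(=O)CCCCCCc3ccccc3)o2)nc1` keeps the same chain and shared core; in this assay compound 2 gives 2.8 nM. Among the compounds with values here, the single measured step, a 5.4-fold lower number from compound 1 to compound 2 (0.73 log units; beyond the scatter), shows that the aromatic group attached to the shared core moves the number beyond the scatter. Within the data shown here, compound 2 thus stands at the lowest of the two numbers so far, with compound 1 as its only comparison at the higher number.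

Compound 3 `O=C(CCCCCCc1ccccc1)c1ncc(-c2nnn[nH]2)o1` is the next step from compound 2: 1H-tetrazol-5-yl in place of 5-methylpyridin-2-yl on an aromatic carbon. Among the measured compounds shown here, no measured step covers a change of this kind; the one step known, a 5.4-fold lower number from compound 1 to compound 2 (0.73 log units; beyond the scatter), only shifts a methyl on the very ring that now leaves, so it offers no direct guide to the size or direction of the step to compound 3. The expectation is a step beyond the scatter toward a higher number, estimated as a 36-fold higher number from compound 2 to compound 3 (1.55 log units; beyond the scatter), with wide uncertainty. Compound 3 is expected to give about 100 nM in this assay, within a range of 15 nM to 700 nM.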

Compound 3, inhibition constant: 63 nM
Compound 3: the middle estimate sits 1.6-fold (0.20 log units) above what was measured, within the range that was stated.
By their numbers in this assay, from the lowest: compound 2; then compound 1; then compound 3.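

In this assay, the place next to the ring oxygen accepts a five-membered aromatic ring with 4 hetero atoms in place of a six-membered one, though with a clear loss against both methylpyridinyl compounds: a 23-fold higher number from compound 2 to compound 3 (1.35 log units; beyond the scatter), and a 4.2-fold higher number from compound 1 to compound 3 (0.62 log units; beyond the scatter). Compound 3 therefore has the highest number of the three, so the 1H-tetrazol-5-yl group falls behind even the 3-methylpyridin-2-yl group, while compound 3 still gives 63 nM with the chain and shared core unchanged. Nothing available accounts for the size of these steps.

Ring size, hetero atom count and the hydrogen-bond donor all change together in this replacement, so the compounds shown cannot assign the steps to any one of them. Going by these compounds, it also remains open how a 1-methyl-1H-tetrazol-5-yl group, which lacks the ring hydrogen, or a carboxylic acid at the same place would compare with compound 3.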